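Chloro for Methyl on Two Related Cores in Cytotoxicity

The compounds below may be only part of what the source reports. "The series", "measured", "known", "first", "only" and "open" are said of these compounds alone.

Measured in an ADME assay on MT4 cells (Homo sapiens) for cytotoxicity, read by spectrophotometry, with a stated time of 5 days; on this read-out lower numbers stand for higher toxicity in this test and higher numbers for lower toxicity in this test:
Compound 1, `CONC(=S)N/N=C1\C(=O)N(CN2CCN(c3ccc(Cl)cc3)CC2)c2ccc(C)cc21`: 300000 nM
Compound 2, `CCn1cc(C(=O)O)c(=O)c2cc(F)c(N3CCN(CN4C(=O)/C(=N\NC(=S)NO)c5cc(C)ccc54)C(C)C3)c(F)c21`: 244000 nM
Compound 3, `CONC(=S)N/N=C1\C(=O)N(CN2CCN(c3ccc(Cl)cc3)CC2)c2ccc(Cl)cc21`: 229000 nM

Compound 1 and compound 3 share a core and differ only by chloro in place of methyl on an aromatic carbon. The step in this assay is a 1.3-fold lower number from compound 1 to compound 3 (0.12 log units; within the scatter), so the two values sit together and neither can be called the more or less toxic of the pair. Compound 2 carries a different core; how its core differs from that of compound 1 is not broken down here. Its value lies close to those of compound 1 and compound 3, all three within the usual scatter of one another.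

Compound 4, `CCn1cc(C(=O)O)c(=O)c2cc(F)c(N3CCN(CN4C(=O)/C(=N\NC(=S)NO)c5cc(Cl)ccc54)C(C)C3)c(F)c21`, has not yet been measured in this assay. It differs from compound 2 by chloro in place of methyl on an aromatic carbon, the same change as that from compound 1 to compound 3. The expected step for compound 4 is a 1.3-fold lower number from compound 2 to compound 4 (0.11 log units; within the scatter). That expectation rests on the step of a 1.3-fold lower number from compound 1 to compound 3 (0.12 log units; within the scatter) and on compound 2 giving 244000 nM. Compound 4 is therefore estimated at 190000 nM, with a range from 100000 nM to 350000 nM.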

Compound 4, half-maximal cytotoxic concentration: 209000 nM
Compound 4: middle estimate off by 1.1-fold (0.04 log units), on the low side; measured number inside the range.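

Replacing methyl with chloro on an aromatic carbon gives a 1.2-fold lower number from compound 2 to compound 4 (0.07 log units; within the scatter) in this assay, and this step agrees with the one seen on the other core: the same change on two cores in this assay, a 1.3-fold lower number (0.12 log units; within the scatter) from compound 1 to compound 3 and a 1.2-fold lower number (0.07 log units; within the scatter) from compound 2 to compound 4, 1.1-fold (0.05 log units) apart, within the scatter of two such steps. Within these two pairs, then, the change carries from one core to the other with no visible difference, and on neither core can the chloro or the methyl compound be called the more or less toxic. The agreement does not show that the change has a real effect on this read-out, as both steps lie within the scatter, and two such small steps cannot tell whether a larger effect would also carry across the cores.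

The compounds shown leave open whether other groups at this aromatic carbon, such as fluoro, methoxy or an amine, would keep the values on the two cores as close together. They also leave open whether the same agreement would hold on any core beyond these two.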